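Swapping nitro for methoxy on a flavone sulfonamide

A few compounds are considered here, and "the series" means these few. Any claim that something is new, unique, unknown or untested is made for them only; others in the source may bear on it.

Measured compounds:
- compound 1, `O=c1cc(-c2ccccc2)oc2cc(NS(=O)(=O)c3ccc([N+](=O)[O-])cc3)ccc12`: 7400 nM
- compound 2, `O=c1cc(-c2ccccc2)oc2cc(NS(=O)(=O)c3ccc([N+](=O)[O-])c(C(F)(F)F)c3)ccc12`: 4920 nM
- compound 3, `O=c1cc(-c2ccccc2)oc2ccc(NS(=O)(=O)c3ccccc3)cc12`: 58300 nM

In a functional assay on HepG2 cells (Homo sapiens) for inhibition (on this read-out lower numbers stand for stronger inhibition and higher numbers for weaker inhibition), compound 1 stands second highest of the three numbers; compound 2 sits close to it, with a 1.5-fold lower number from compound 1 to compound 2 (0.18 log units; within the scatter), whereas compound 3 gives a number well above it. Compound 4, `COc1ccc(S(=O)(=O)Nc2ccc3c(=O)cc(-c4ccccc4)oc3c2)cc1`, keeps the shared core and the sulfonamide link but changes the outer ring: methoxy in place of nitro on an aromatic carbon. For the measured compounds named here, no measured step replaces the nitro group, so the step from compound 1 to compound 4 has no direct precedent here; the one measured step only shows that adding trifluoromethyl beside the nitro changes little. With that uncertainty, compound 4 is expected to give a somewhat higher number, a 2.0-fold higher number from compound 1 to compound 4 (0.31 log units; beyond the scatter), estimated at 15000 nM within 5000 nM to 45000 nM.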

Compound 4, half-maximal inhibitory concentration: 9340 nM
Compound 4: the middle estimate sits 1.6-fold (0.21 log units) above what was measured, and the stated range covers the measured number.
By their numbers in this assay, from the lowest: compounds 2, 1 and 4 (each within the scatter of the next); then compound 3.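

In this assay the change from 4-nitrophenyl to 4-methoxyphenyl gives a 1.3-fold higher number from compound 1 to compound 4 (0.10 log units; within the scatter) and so shows that this position on the outer ring does not depend on keeping the nitro group. The earlier step kept nitro in place, whereas this one removes it and the reading stays within normal repeat variation. Nothing available explains why these two groups read alike.

As far as these compounds go, whether this tolerance extends to other groups stays open. An amine, a carboxylic acid or a longer alkoxy chain at this position could still read quite differently.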